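Replacing 1-Methylethenyl on Compound 2: A Vinyloxy Analogue Awaits

A few compounds are considered here, and "the series" means these few. Any claim that something is new, unique, unknown or untested is made for them only; others in the source may bear on it.

Of the compounds shown here, three that share a common core have been measured in an assay on CHO cells with Alpha-2C adrenergic receptor (Homo sapiens) as the target; a higher number here means a larger maximal response, a lower number a smaller maximal response. Compound 1 `C=CCc1cccc(CC=C)c1OC(C)C1=NCCN1` gives 0.9 in this assay. Compound 3 `CC(Oc1ccccc1Br)C1=NCCN1` gives 0.87. Compound 2 `C=C(C)c1ccccc1OC(C)C1=NCCN1` gives 0.71, the lowest of the three numbers; compound 3 stands nearest to it, separated by a number 0.16 higher from compound 2 to compound 3 (beyond the scatter), while compound 1 is the furthest away, and both gaps lie beyond the scatter.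

Compound 4 `C=COc1ccccc1OC(C)C1=NCCN1` has not yet been measured in this assay. It differs from compound 2 in one place: vinyloxy in place of 1-methylethenyl on an aromatic carbon.

Among the compounds with values here, only one measured step bears on this change, namely the one that likewise removes 1-methylethenyl from compound 2: a number 0.16 higher from compound 2 to compound 3 (beyond the scatter), a modest rise beyond the scatter. The group entering there was bromo rather than vinyloxy, so the comparison is loose. Because the step a number 0.16 higher from compound 2 to compound 3 (beyond the scatter) raised the number when 1-methylethenyl left compound 2, a rise of similar direction is expected for compound 4, probably modest, and quite possibly within the scatter. Compound 4 is therefore expected to give about 0.82, with a range from 0.68 to 0.95. The expected change in this assay amounts to a number 0.11 higher from compound 2 to compound 4 (beyond the scatter).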

Compound 4, intrinsic activity: the largest response reached, as a fraction of the reference agonist's: 0.48
Beside the measured number, compound 4's estimate is 0.34 above it, outside the stated range (below it).
By their numbers in this assay, from the lowest: compound 4; then compound 2; then compounds 3 and 1 (each within the scatter of the next).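

Within the data shown here, until now the only change at this aromatic carbon, bromo in place of 1-methylethenyl, had raised the maximal response, so removing 1-methylethenyl might have seemed favourable in itself. In this assay vinyloxy reverses that direction, with a number 0.23 lower from compound 2 to compound 4 (beyond the scatter), and the two entering groups are far apart, with a number 0.39 lower from compound 3 to compound 4 (beyond the scatter), so the outcome here depends on which group enters and not merely on the loss of 1-methylethenyl. The fall also occurs although vinyloxy and 1-methylethenyl have equal heavy-atom counts and each has a double bond outside aromatic rings, the counted differences being an oxygen in place of a carbon and a hydrogen-bond acceptor; no evidence is available to explain the lower response.

From the compounds shown here alone, whether the fall follows the oxygen or the vinyloxy group as a whole remains open, and a methoxy or an ethyl group on this aromatic carbon would help to separate those readings. Compound 1 differs from the other compounds in more than one place, so it offers no direct reading of this change.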